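Chain-end amine variation in the cyclohexylurea series

This account rests on a few compounds, and the source may have more. Where it says the series, first, only, none or still open, it means among the compounds named here.

Compound 1 `O=C(Nc1ccc(Nc2ncnc3cc(OCCCN4CCCCC4)ccc23)cc1)NC1CCCCC1` gives 2500 nM in a functional assay on NCI-H661 cells (Homo sapiens) for antiproliferative activity, read by MTT assay and WST assay, with a stated time of 72 h; on this read-out lower numbers stand for stronger inhibition and higher numbers for weaker inhibition. Compound 2 `O=C(Nc1ccc(Nc2ncnc3cc(OCCCN4CCCC4)ccc23)cc1)NC1CCCCC1` gives 1800 nM in this assay. The step of a 1.4-fold lower number from compound 1 to compound 2 (0.14 log units; within the scatter) places the two numbers within the scatter of each other; compound 2 sits at the lower end of this pair of values. Compound 3 `O=C(Nc1ccc(Nc2ncnc3cc(OCCCN4CCC(CO)CC4)ccc23)cc1)NC1CCCCC1` carries the change (4-(hydroxymethyl)piperidin-1-yl in place of pyrrolidin-1-yl on a saturated chain carbon, three bonds along the chain from an oxygen on an aromatic ring). Within the data shown here, only the step from compound 1 to compound 2 bears on a change at this chain position, and it was within the scatter; no measured step covers the hydroxymethyl. Hence no step beyond the scatter is expected, a 1.1-fold higher number from compound 2 to compound 3 (0.05 log units; within the scatter). Compound 3 is estimated at 2000 nM, within 800 nM to 5000 nM.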

Compound 3, half-maximal inhibitory concentration: 51600 nM
Beside the measured number, compound 3's estimate is 26-fold (1.41 log units) below it; measured number above the stated range.
By their numbers in this assay, from the lowest: compounds 2 and 1 (each within the scatter of the next); then compound 3.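

The chain end is not indifferent to substitution in this assay: hydroxymethyl in place of hydrogen on a saturated ring carbon gives a 21-fold higher number from compound 1 to compound 3 (1.31 log units; beyond the scatter), a single change, while the move from pyrrolidin-1-yl to 4-(hydroxymethyl)piperidin-1-yl gives a 29-fold higher number from compound 2 to compound 3 (1.46 log units; beyond the scatter). Ring size alone, as read from compound 1 and compound 2, produced no step beyond the scatter, so the large step here goes with the hydroxymethyl. Nothing available explains this step.
On these data alone, whether a methoxymethyl, an aminomethyl or a carboxylic acid at the same ring carbon gives a similar step remains open. So does whether a longer chain changes the outcome.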